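Hydroxy for Methoxy in a Cell-Growth Inhibition Series

A few compounds are considered here, and "the series" means these few. Any claim that something is new, unique, unknown or untested is made for them only; others in the source may bear on it.

Two compounds with a shared core were tested in a functional assay on T47D cells (Homo sapiens) for inhibition, read by sulforhodamine B assay, with a stated time of 48 h; a lower number here means that less compound is tolerated, a higher number that more compound is tolerated. Compound 1 `O=C(Nc1cccc(-n2cc(-c3ccncc3)c(-c3ccc(Cl)c(O)c3)n2)c1)Nc1cccc(C(F)(F)F)c1` carries a trifluoromethyl on its outer ring and a hydroxy on the chlorophenyl ring. In this assay compound 1 gives only > 32500 nM, which is a limit of the assay rather than a number (the limit of > 32500 nM in this assay, at which 1 of the 2 values shown sits). Compound 2 `COc1cc(-c2nn(-c3cccc(NC(=O)Nc4ccc(Cl)c(Cl)c4)c3)cc2-c2ccncc2)ccc1Cl` carries two chlorines on its outer ring and a methoxy in place of the hydroxy. In this assay compound 2 likewise gives only > 50000 nM, again a limit and not a measured value (the limit of > 50000 nM in this assay, at which 1 of the 2 values shown sits). Among the measured compounds shown here, no step between compounds that differ in one place is available, so neither reading can be ranked against the other.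

Compound 3 `O=C(Nc1cccc(-n2cc(-c3ccncc3)c(-c3ccc(Cl)c(O)c3)n2)c1)Nc1ccc(Cl)c(Cl)c1` has not yet been measured. It differs from compound 2 by hydrogen in place of methyl on an oxygen on an aromatic ring. The expected step is a number no higher from compound 2 to compound 3 (the limit leaves the size open), none beyond the scatter, and a reading at the reporting limit is expected again. For compound 3 the estimate in this assay is 50000 nM, with a range from 15000 nM to 150000 nM.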

Compound 3, concentration lethal to 50% of the cells: > 32500 nM
Compound 3: a limit, no number; the forecaster's own chance of this, stated with the estimate: 75%; the middle value is on the limit's open side.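

In this assay compound 3 gives > 32500 nM, a limit of the assay and not a number. All three readings are limits, so neither the step from compound 2 to compound 3 nor that from compound 1 to compound 3 can be read. The compounds shown leave open whether methoxy to hydroxy, or 3-(trifluoromethyl)phenyl to 3,4-dichlorophenyl, changes the reading in this assay at all.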